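Replacing 2,4-dichlorophenyl with 3-nitrophenyl on a shared core

The source may report more compounds than this note shows. Statements on the series, on what has been measured and on what is new or still open speak of the compounds shown alone.

In a functional assay on HeLa cells (Homo sapiens) for cytotoxicity, read by MTT assay, with a stated time of 24 h (on this read-out higher numbers stand for weaker inhibition and lower numbers for stronger inhibition), compound 1 `COc1cc(/C=C2\CN(C)C/C(=C\c3ccccc3F)C2=O)cc(OC)c1OC` gives 3220 nM. Compound 2 `COc1cc(/C=C2\CN(C)C/C(=C\c3ccc(Cl)cc3Cl)C2=O)cc(OC)c1OC` stands at > 20000 nM, which is a limit of this assay and not a number. Compound 3 `COc1cc(/C=C2\CN(C)C/C(=C\c3cccc([N+](=O)[O-])c3)C2=O)cc(OC)c1OC` differs from compound 2 by 3-nitrophenyl in place of 2,4-dichlorophenyl on a double-bonded chain carbon bound to a double-bonded ring carbon, with 3-nitrophenyl in place of 2,4-dichlorophenyl on a double-bonded chain carbon bound to a double-bonded ring carbon. Within the data shown here, the only measured step at this place is an at least 6.2-fold higher number from compound 1 to compound 2 (0.79 log units; beyond the scatter), so losing 2,4-dichlorophenyl is expected to bring a lower number, towards stronger inhibition. The expected change is an at least 4.0-fold lower number from compound 2 to compound 3 (0.60 log units; beyond the scatter). For compound 3 the estimated value is 5000 nM, within an expected range of 1500 nM to 20000 nM.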

Compound 3, half-maximal inhibitory concentration: 5540 nM
The estimate for compound 3 lay 1.1-fold (0.04 log units) below the measured number; measured number inside the range.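

In this assay, 3-nitrophenyl at this place brings the series back from the limit to a measured value (an at least 3.6-fold lower number from compound 2 to compound 3 (0.55 log units; beyond the scatter)). Compound 2 is held only by a limit of the assay, not a number: the limit of > 20000 nM in this assay, at which 1 of the 3 values shown sits. The 3-nitrophenyl and 2-fluorophenyl groups cannot be told apart here (a 1.7-fold higher number from compound 1 to compound 3 (0.24 log units; within the scatter)), so 2,4-dichlorophenyl alone stands apart among these three compounds.

Going by these compounds, whether a phenyl ring carrying a single chlorine would stay measurable remains open. So does the outcome for an amine or a carboxylic acid on the phenyl ring in place of the nitro group.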